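A few compounds are considered here, and "the series" means these few. Any claim that something is new, unique, unknown or untested is made for them only; others in the source may bear on it.

Compound 1 `COc1ccc(N2C(=O)COc3ccc(-c4cnc(OC)c(NS(=O)(=O)c5ccc(F)cc5)c4)cc32)cc1` stands at the lower of the two numbers measured in a functional assay on A549 cells (Homo sapiens) for antiproliferative activity, read by MTT assay, with a stated time of 72 h; on this read-out lower numbers stand for stronger inhibition and higher numbers for weaker inhibition: compound 1 gives 1350 nM. Going by the values given here, its only measured neighbour is compound 2 `COc1ccc(N2C(=O)COc3ccc(-c4cnc(Cl)c(NS(=O)(=O)c5ccc(F)cc5)c4)cc32)cc1`, which in this assay gives 30400 nM; that step, a 23-fold higher number from compound 1 to compound 2 (1.35 log units; beyond the scatter), came with chloro in place of methoxy on an aromatic carbon. Compound 3 `COc1cccc(N2C(=O)COc3ccc(-c4cnc(OC)c(NS(=O)(=O)c5ccc(F)cc5)c4)cc32)c1` has not yet been measured. It differs from compound 1 at another site: 3-methoxyphenyl in place of 4-methoxyphenyl on an amide-type nitrogen in a ring. Among the compounds with values here, no measured step touches the group on the amide-type nitrogen in a ring, so the one step that is known, between compound 1 and compound 2, concerns a different part of the shared core and does not bear on this change directly. With nothing to indicate a direction, the expectation for compound 3 is a step of about a 1.5-fold higher number from compound 1 to compound 3 (0.17 log units; within the scatter) in this assay, that is, no change beyond the scatter. Compound 3 is therefore estimated to give 2000 nM in this assay, with a range from 600 nM to 7000 nM.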

Compound 3, half-maximal inhibitory concentration: 11200 nM
Compound 3: the middle estimate sits 5.6-fold (0.75 log units) below what was measured; the measured number lies above the stated range.
By their numbers in this assay, from the lowest: compound 1; then compound 3; then compound 2.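

Placing 3-methoxyphenyl in place of 4-methoxyphenyl on the amide-type nitrogen in a ring leaves the atom count unchanged, yet in this assay it gives an 8.3-fold higher number from compound 1 to compound 3 (0.92 log units; beyond the scatter), so this site responds to where the methoxy group sits on the phenyl ring and not only to which atoms are present. The earlier pair had shown sensitivity only at the other site, where chloro in place of methoxy on an aromatic carbon gives a 23-fold higher number from compound 1 to compound 2 (1.35 log units; beyond the scatter); the series now has two separate sites at which a single change from compound 1 raises the number beyond the scatter. Compound 1 thus holds the lowest number of the three, and nothing measured here says why the change at the amide-type nitrogen has this effect.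

On these data alone, it remains open what a plain phenyl, a 4-ethoxyphenyl or a 4-(dimethylamino)phenyl on that nitrogen would give, and so whether the methoxy group itself contributes to the number of compound 1. Also open, as far as these compounds go, is whether the effect of this change would carry over to a compound bearing chloro at the other site.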